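Swapping a Benzyl Group for Bromine on a Benzoate Ester

The source may hold more compounds than are shown below. What is called first, only, known or untested is meant among the compounds shown, and "the series" means these compounds.

Compound 1 `CN1CCC(OC(=O)c2ccccc2Cc2ccccc2)CC1` gives 1.28 in a functional assay on the whole organism with Mus musculus as the target; on this read-out lower numbers stand for lower potency and higher numbers for higher potency (the scale is a negative logarithm).
Compound 2 `CN1CCC(OC(=O)c2ccc(C#N)cc2)CC1` gives 1.65 in this assay.

For the measured compounds named here, of the two numbers measured so far, compound 1 stands lowest; compound 2 lies higher by a margin that is beyond the usual scatter of repeated measurements, so the two are genuinely told apart. Compound 3 `CN1CCC(OC(=O)c2ccccc2Br)CC1` has not yet been measured. It differs from compound 1 in one place: bromo in place of benzyl on an aromatic carbon. Going by the values given here, no measured pair shows this particular change, so nothing in the data says directly how large its effect is. A small step is expected, likely upward, though one that may well stay within the scatter: the step from compound 1 to compound 3 is estimated at a number 0.22 log units higher from compound 1 to compound 3 (within the scatter). For compound 3 the estimated value in this assay is 1.5, with a plausible range from 1 to 2.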

Compound 3, logarithm of the reciprocal of the active concentration, log(1/C): 1.21
For compound 3 the middle estimate is 0.29 log units above the measured one; the measured number falls inside the stated range.
By their numbers in this assay, from the lowest: compounds 3 and 1 (each within the scatter of the next); then compound 2.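

In this assay, bromo in place of benzyl on this aromatic carbon, ortho to a large group, gives a number 0.07 log units lower from compound 1 to compound 3 (within the scatter). For the compounds shown here, this is the first measured pair that differs in one place, and it shows that going from 7 heavy atoms with a ring to 1 heavy atom without a ring does not separate the two compounds on this read-out. No measurement shown here accounts for this result.

Going by these compounds, a single pair cannot show whether other groups at this position would behave the same way, so it remains open whether an amine, a carboxylic acid or a longer chain would move the number beyond the scatter. On these data alone, it also remains open whether this result would hold on a different core.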